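Replacing the nitro group of compound 2 with butyl

The compounds below may be only part of what the source reports. "The series", "measured", "known", "first", "only" and "open" are said of these compounds alone.

Compound 1 (`CC(=O)N1N=C(c2ccc(Cl)cc2)OC1c1ccc([N+](=O)[O-])o1`) and compound 2 (`CC(=O)N1N=C(c2ccc([N+](=O)[O-])cc2)OC1c1ccc([N+](=O)[O-])o1`) differ in a single group on the shared core, chloro in one and nitro in the other. In an ADME assay on J774 cells (Mus musculus) for cytotoxicity, read by MTT assay, with a stated time of 48 h (a higher number here means a weaker inhibitor, a lower number a stronger inhibitor), compound 1 gives > 400000 nM, which is a limit of the assay and not a number. Going by the values given here, compound 2 gives 114000 nM, the only true number available so far.

Compound 3 (`CCCCc1ccc(C2=NN(C(C)=O)C(c3ccc([N+](=O)[O-])o3)O2)cc1`) has butyl in place of nitro on an aromatic carbon. Among the compounds with values here, one measured step bears on this change, and it is an at least 3.5-fold lower number from compound 1 to compound 2 (0.54 log units; beyond the scatter). Butyl has not been measured here, and chloro is only a loose guide to it. Still, compound 3 gives up the nitro group, and bringing nitro in went with the lower number in that step, an at least 3.5-fold lower number from compound 1 to compound 2 (0.54 log units; beyond the scatter), so a move back towards a higher number is expected. The expected change is a 2.2-fold higher number from compound 2 to compound 3 (0.34 log units; beyond the scatter), and it is uncertain. For compound 3 the estimated value is 250000 nM, with an expected range from 90000 nM to 600000 nM.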

Compound 3, half-maximal inhibitory concentration: > 400000 nM
Compound 3: only a limit was reported; the forecaster's own chance of this, stated with the estimate: 35%; at least 1.6-fold (0.20 log units) between middle value and limit.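

In this assay compound 3 gives > 400000 nM, which is a limit of the assay and not a number. Butyl in place of nitro gives an at least 3.5-fold higher number from compound 2 to compound 3 (0.54 log units; beyond the scatter), so compound 2 now stands apart from two neighbours, one carrying chloro and one carrying butyl, and among the compounds shown the lower number at this position goes with nitro alone. Because both other compounds sit at the limit, the step between compound 1 and compound 3 cannot be read, and chloro and butyl cannot be put in order: the limit of > 400000 nM in this assay, at which 2 of the 3 values shown sit.

Going by these compounds, it remains open whether the lower number is particular to nitro or would also appear with another group on this aromatic carbon, such as an amine, a carboxylic acid or a nitrile. Also open, on these data alone, is how a chain longer than butyl would read here, and whether the change from nitro to butyl would read the same way on a different core.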